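Ring enlargement with a new double bond in the side chain

The source may hold more compounds than are shown below. What is called first, only, known or untested is meant among the compounds shown, and "the series" means these compounds.

Compound 1 `COC(=O)CC/C=C\CC[C@H]1C(=O)C[C@@H](O)[C@@H]1/C=C/CC(C)(O)CCC1CC1` is a prostaglandin-like ester; in a functional assay on the whole organism (stomach) with Canis familiaris (Canis lupus familiaris) as the target (a lower number here means that less compound is needed, a higher number that more compound is needed for the effect), compound 1 gives 0.00009 mg/kg. Compound 2 `COC(=O)CC/C=C\CC[C@H]1C(=O)C[C@@H](O)[C@@H]1/C=C/CC(C)(O)CCC1CCC1` differs only by a cyclobutyl ring, and compound 2 gives 0.00009 mg/kg, so the step of no change at the digits printed from compound 1 to compound 2 (within the scatter) lies within the scatter. Compound 3 `COC(=O)CC/C=C\CC[C@H]1C(=O)C[C@@H](O)[C@@H]1/C=C/C[C@@](C)(O)/C=C/C1CCCC1` carries the change (3-cyclopentyl-1-hydroxy-1-methylprop-2-en-1-yl in place of 3-cyclopropyl-1-hydroxy-1-methylpropyl on a saturated chain carbon bound to a double-bonded chain carbon). Within the data shown here, the ring enlargement resembles the step to compound 2, but the added double bond has no measured precedent here. The step of a 1.1-fold higher number from compound 1 to compound 3 (0.05 log units; within the scatter) is therefore expected to be small. For compound 3 the expected value is 0.0001 mg/kg, with a range from 0.00003 mg/kg to 0.0004 mg/kg.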

Compound 3, dose for half-maximal effect: 0.0003 mg/kg
Beside the measured number, compound 3's estimate is 3.0-fold (0.48 log units) below it; low and high end bracket the measured number.
By their numbers in this assay, from the lowest: compounds 1 and 2 (each within the scatter of the next); then compound 3.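

In this assay, this side-chain position now shows a step beyond the scatter, a 3.3-fold higher number from compound 1 to compound 3 (0.52 log units; beyond the scatter) and likewise a 3.3-fold higher number from compound 2 to compound 3 (0.52 log units; beyond the scatter). Among these compounds, the earlier swap of cyclopropyl for cyclobutyl gave no such step, so this position is not indifferent to every change. The 3-cyclopentyl-1-hydroxy-1-methylprop-2-en-1-yl group differs in ring size, double bond and defined stereocentre at once, and these cannot be separated here.

Going by these compounds, it remains open which of these differences carries the step, and how a phenyl ring or an amine at the chain end would read. No measurement available here offers an explanation for the step.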